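The source may report more compounds than this note shows. Statements on the series, on what has been measured and on what is new or still open speak of the compounds shown alone.

Measured so far in a functional assay on PC-3 cells (Homo sapiens) for cytotoxicity, read by WST assay, with a stated time of 24 h; on this read-out higher numbers stand for weaker inhibition and lower numbers for stronger inhibition:
- compound 1 `N#C/C(=C\c1cn(Cc2ccc(Cl)cc2)c2ccccc12)C(=O)c1c[nH]c2cc(F)ccc12` gives > 50000 nM as a limit
- compound 2 `COc1ccc2c(C(=O)/C(C#N)=C/c3cn(Cc4ccc(Cl)cc4)c4ccccc34)c[nH]c2c1` gives > 50000 nM as a limit

Compound 2 stands at > 50000 nM as a limit and not as a number. Both measured compounds share this one reading (the limit of > 50000 nM in this assay, at which 2 of the 2 values shown sit). Compound 3 `N#C/C(=C\c1cn(Cc2ccc(Cl)cc2)c2ccccc12)C(=O)c1c[nH]c2ccccc12` carries hydrogen in place of methoxy on an aromatic carbon and so has 1H-indol-3-yl where compound 2 has 6-methoxy-1H-indol-3-yl. Within the data shown here, the only measured step bearing on this change is a step that the two limits leave unreadable from compound 1 to compound 2 and it exchanges fluoro for methoxy. Among the measured compounds shown here, with that step as the only guide, no change beyond the scatter is expected in this assay in either direction. The expected size is a number no higher from compound 2 to compound 3 (the limit leaves the size open) on this reading. For compound 3 the estimated value is 50000 nM with an expected range from 20000 nM to 100000 nM and another limit is the likeliest report.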

Compound 3, half-maximal inhibitory concentration: > 50000 nM
Compound 3 was reported as a limit; the forecaster's own chance of this, stated with the estimate: 75%; the middle value sits exactly at the limit.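

Among these compounds, no step among compound 1, compound 2 and compound 3 can be read, because all three results are limits and not numbers: the limit of > 50000 nM in this assay, at which 3 of the 3 values shown sit. The compounds shown leave open whether fluoro, methoxy or hydrogen at this place on the shared core makes any difference to the result.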